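From a nitrophenyl to a bromophenyl: estimating compound 4

The source may hold more compounds than are shown below. What is called first, only, known or untested is meant among the compounds shown, and "the series" means these compounds.

Measured in a functional assay on NRK-49F cells (Rattus norvegicus) for cytotoxicity, read by MTT assay, with a stated time of 24 h; on this read-out lower numbers stand for stronger inhibition and higher numbers for weaker inhibition
- compound 1 (`COc1cc(/C=C(\C#N)C(=O)N/N=C(\C)c2c(O)c3ccc(O)cc3oc2=O)ccc1O`) gives 55400 nM
- compound 2 (`COc1ccc(/C=C(\C#N)C(=O)N/N=C(\C)c2c(O)c3ccc(O)cc3oc2=O)cc1`) gives 96100 nM
- compound 3 (`C/C(=N\NC(=O)/C(C#N)=C/c1ccc([N+](=O)[O-])cc1)c1c(O)c2ccc(O)cc2oc1=O`) gives 43200 nM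

Compound 3 sits at the low end of these three numbers. Its nearest step is a 1.3-fold lower number from compound 1 to compound 3 (0.11 log units; within the scatter) and its furthest is a 2.2-fold lower number from compound 2 to compound 3 (0.35 log units; beyond the scatter). Compound 4 (`C/C(=N\NC(=O)/C(C#N)=C/c1cccc(Br)c1)c1c(O)c2ccc(O)cc2oc1=O`) has not been measured yet. It carries 3-bromophenyl in place of 4-nitrophenyl on a double-bonded chain carbon bound to a double-bonded chain carbon. The remaining step at this place, a 1.7-fold higher number from compound 1 to compound 2 (0.24 log units; within the scatter), was also small. Among the measured compounds shown here, no bromine-bearing compound has been measured, so these steps are only a rough guide. In this assay no change beyond the scatter is expected. The expected step is a 1.3-fold higher number from compound 3 to compound 4 (0.10 log units; within the scatter). For compound 4 the estimated value is 55000 nM, with an expected range from 25000 nM to 115000 nM.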

Compound 4, half-maximal inhibitory concentration: 59400 nM
Estimate against measurement, compound 4: 1.1-fold (0.03 log units) below; measured number inside the range.
By their numbers in this assay, from the lowest: compounds 3, 1, 4 and 2 (each within the scatter of the next, the first and the last beyond it).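

In this assay, among the compounds shown here, 3-bromophenyl, the first group here to carry bromine, stays within the scatter of all three earlier groups (a 1.4-fold higher number from compound 3 to compound 4 (0.14 log units; within the scatter); a 1.6-fold lower number from compound 2 to compound 4 (0.21 log units; within the scatter); a 1.1-fold higher number from compound 1 to compound 4 (0.03 log units; within the scatter)). Replacing 4-nitrophenyl, with its 2 hydrogen-bond acceptors, by a group with 0 therefore gives no change beyond the scatter at this place. Nothing measured here explains this result. The compounds shown leave open whether 4-bromophenyl would match 3-bromophenyl, and whether a phenyl ring bearing an amine or a carboxylic acid would give a step beyond the scatter.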